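Dimethoxy for Bromine on the Benzyl Group of Compound 2

The compounds below may be only part of what the source reports. "The series", "measured", "known", "first", "only" and "open" are said of these compounds alone.

Compound 2 `OC[C@H]1O[C@@H](n2cnc3c(NCc4cccc(Br)c4)ncnc32)[C@H](O)[C@@H]1O` gives 5000 nM in a functional assay on CCRF-CEM cells (Homo sapiens) for antiproliferative activity, with a stated time of 72 h (a lower number here means a stronger inhibitor, a higher number a weaker inhibitor), and stands lowest of the two numbers here; compound 1 `OC[C@H]1O[C@@H](n2cnc3c(NCc4ccccc4Cl)ncnc32)[C@H](O)[C@@H]1O` gives 14500 nM, a step of a 2.9-fold lower number from compound 1 to compound 2 (0.46 log units; beyond the scatter). Compound 3 `COc1cccc(CNc2ncnc3c2ncn3[C@@H]2O[C@H](CO)[C@@H](O)[C@H]2O)c1OC` reaches only the limit of this assay, > 166000 nM. Compound 4 `COc1ccc(CNc2ncnc3c2ncn3[C@@H]2O[C@H](CO)[C@@H](O)[C@H]2O)c(OC)c1` differs from compound 2 by 2,4-dimethoxyphenyl in place of 3-bromophenyl on a saturated chain carbon bound to a nitrogen on an aromatic ring. For the measured compounds named here, the closest measured step is the one to compound 3, a 2,3-dimethoxyphenyl in place of 3-bromophenyl, which gave an at least 33-fold higher number from compound 2 to compound 3 (1.52 log units; beyond the scatter); from compound 1 the same change gave an at least 11-fold higher number from compound 1 to compound 3 (1.05 log units; beyond the scatter). Both dimethoxy steps are large and in the same direction, so a large rise in number is expected for compound 4, an estimated 24-fold higher number from compound 2 to compound 4 (1.38 log units; beyond the scatter), bringing it to about 120000 nM, between 30000 nM and 400000 nM, with a real chance the assay reports only a limit (the limit of > 166000 nM in this assay, at which 1 of the 3 values shown sits).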

Compound 4, half-maximal inhibitory concentration: > 166000 nM
Compound 4 was reported as a limit (the forecaster's own chance of this, stated with the estimate: 55%); middle value at least 1.3-fold (0.14 log units) from the limit.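

A second dimethoxy pattern on the benzyl group now gives the same outcome as the first: an at least 33-fold higher number from compound 2 to compound 4 (1.52 log units; beyond the scatter), and an at least 11-fold higher number from compound 1 to compound 4 (1.05 log units; beyond the scatter). In this assay, the rise in number seen with 2,3-dimethoxyphenyl is therefore not confined to that one pattern. Compound 4 is reported only as a limit, and so is compound 3, so the step between them cannot be read: the limit of > 166000 nM in this assay, at which 2 of the 4 values shown sit.

From the compounds shown here alone, how a single methoxy group in place of the bromine of compound 2 would behave remains open. So does the effect of an amine or a carboxylic acid on that ring.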